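A few compounds are considered here, and "the series" means these few. Any claim that something is new, unique, unknown or untested is made for them only; others in the source may bear on it.

Measured so far in a functional assay, read by spectrophotometry, with a stated time of 5 min; on this read-out lower numbers stand for stronger inhibition and higher numbers for weaker inhibition:
compound 1 `O=c1[nH]c2ccccc2cc1/C=N/CCO` gives 467000 nM;
compound 2 `N/N=C/c1cc2ccccc2[nH]c1=O` gives 184000 nM;
compound 3 `CCCC/N=C/c1cc2ccccc2[nH]c1=O` gives 246000 nM.

Among the compounds with values here, compound 2 shows the lowest number of the three, though only the step of a 2.5-fold lower number from compound 1 to compound 2 (0.40 log units; beyond the scatter) lies beyond the scatter, while a 1.3-fold higher number from compound 2 to compound 3 (0.13 log units; within the scatter) lies within it. Compound 4 `O=c1[nH]c2ccccc2cc1/C=N/Nc1ccccc1` differs from compound 2 by phenyl in place of hydrogen on an amine nitrogen. Within the data shown here, no measured step alters that amine nitrogen itself; the nearest guides are the swaps on the double-bonded nitrogen, where a 1.3-fold higher number from compound 2 to compound 3 (0.13 log units; within the scatter) and a 1.9-fold lower number from compound 1 to compound 3 (0.28 log units; within the scatter) stayed within the scatter and a 2.5-fold lower number from compound 1 to compound 2 (0.40 log units; beyond the scatter) was modest. A step in this assay of no more than the scatter is therefore expected, with a slight lean toward lower numbers. Compound 4 is estimated at 150000 nM, with a range from 50000 nM to 400000 nM. The expected step is a 1.2-fold lower number from compound 2 to compound 4 (0.09 log units; within the scatter).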

Compound 4, half-maximal inhibitory concentration: 306000 nM
For compound 4 the middle estimate is 2.0-fold (0.31 log units) below the measured one; measured number inside the range.
By their numbers in this assay, from the lowest: compounds 2, 3, 4 and 1 (each within the scatter of the next, the first and the last beyond it).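

In this assay, the amine nitrogen of compound 2 takes a far larger group than hydrogen, a phenyl of six carbons, with only a small shift in the number (a 1.7-fold higher number from compound 2 to compound 4 (0.22 log units; within the scatter)). Within the data shown here, this is the first change made on that nitrogen itself, and for this one pair, added bulk there brings no gain in inhibition beyond the scatter. Nothing on hand explains this result.

From the compounds shown here alone, whether a smaller methyl, a benzyl or a phenyl bearing a carboxylic acid on that nitrogen would behave the same remains open.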